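This account rests on a few compounds, and the source may have more. Where it says the series, first, only, none or still open, it means among the compounds named here.

Measured in a functional assay on the whole organism with Scenedesmus acutus as the target; on this read-out higher numbers stand for weaker inhibition and lower numbers for stronger inhibition:
Compound 1 `O=C(O)c1cc(N2C(=O)C3=C(CCCC3)C2=O)ccc1Cl`: > 100000 nM
Compound 2 `COC(=O)c1cc(N2C(=O)C3=C(CCCC3)C2=O)ccc1Cl`: 2000 nM
Compound 3 `CCCCOC(=O)c1cc(N2C(=O)C3=C(CCCC3)C2=O)ccc1Cl`: 3550 nM

Compound 1 gives only a limit of the assay, > 100000 nM, and not a true number. Among the measured compounds shown here, compound 3, at 3550 nM, lies within the scatter of compound 2, the only other compound with a true number.

Compound 4 `C#CCOc1cc(N2C(=O)C3=C(CCCC3)C2=O)ccc1Cl` keeps the shared core but has propargyloxy in place of butoxycarbonyl on an aromatic carbon, ortho to a chloro group: propargyloxy in place of butoxycarbonyl on an aromatic carbon.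

For the measured compounds named here, three measured steps bear on this change. Replacing the hydrogen on the oxygen had a large effect in both cases, with an at least 50-fold lower number from compound 1 to compound 2 (1.69 log units; beyond the scatter) and an at least 28-fold lower number from compound 1 to compound 3 (1.44 log units; beyond the scatter). Lengthening the chain had little effect, with a 1.8-fold higher number from compound 2 to compound 3 (0.25 log units; within the scatter). None of these steps removes the carbonyl group, so the swap in compound 4 goes beyond what has been measured and any forecast is uncertain. Since the chain length mattered little between compound 2 and compound 3, a return to the limit seen for compound 1 seems unlikely, and a modest move to a lower number is the tentative expectation.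

The expected change is a 3.6-fold lower number from compound 3 to compound 4 (0.55 log units; beyond the scatter). The estimate for compound 4 is 1000 nM, with an expected range of 100 nM to 8000 nM.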

Compound 4, half-maximal inhibitory concentration: 79.4 nM
For compound 4 the middle estimate is 13-fold (1.10 log units) above the measured one; the whole stated range lies above it.
By their numbers in this assay, from the lowest: compound 4; then compounds 2 and 3 (each within the scatter of the next). At a limit, above all of these: compound 1.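

In this assay, among the compounds shown here, the earlier compounds varied only the chain on an ester, whereas this change removes the carbonyl altogether, and the result shows that a carbonyl is not required at this position, on an aromatic carbon ortho to a chloro group: butoxycarbonyl to propargyloxy gives a 45-fold lower number from compound 3 to compound 4 (1.65 log units; beyond the scatter), and methoxycarbonyl to propargyloxy gives a 25-fold lower number from compound 2 to compound 4 (1.40 log units; beyond the scatter). The smaller propargyloxy group, with no carbonyl, therefore gives the lowest number of the set, beyond the scatter of both esters, and against the carboxy group the change reads an at least 1200-fold lower number from compound 1 to compound 4 (3.10 log units; beyond the scatter). The true size of that last step stays unknown, as compound 1 gives only a limit of the assay and not a true number: the limit of > 100000 nM in this assay, at which 1 of the 4 values shown sits.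

The compounds shown leave open whether the ether oxygen on the ring or the triple bond at the end of the chain matters more, as the swap changes both at once. A propoxy group, which has no triple bond, would separate the two, and an amine at this position or a longer chain ending in a triple bond would show how much room there is for other groups here.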